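Defining one stereocentre in the side chain of compound 2

A few compounds are considered here, and "the series" means these few. Any claim that something is new, unique, unknown or untested is made for them only; others in the source may bear on it.

Compound 2 `OCC(O)COc1nc(N2CCCCC2)c2nc(OCC(O)CO)nc(N3CCCCC3)c2n1` is one of two compounds with a result in a functional assay on L1210 cells (Mus musculus) for inhibition, read by thymidine incorporation, tested at 10 uM, in the presence of a further agent that is not named here; a higher number here means more inhibition at the concentration tested (going by the name of the read-out), a lower number less inhibition. In this assay compound 2 gives 34%. It stands lowest of the two numbers; the nearest, compound 1 `C[C@H](O)COc1nc(N2CCCCC2)c2nc(OC[C@@H](C)O)nc(N3CCCCC3)c2n1`, sits a long way above it, beyond the scatter: in this assay compound 1 gives 69%. Compound 3 `OCC(O)COc1nc(N2CCCCC2)c2nc(OC[C@@H](O)CO)nc(N3CCCCC3)c2n1` has no result yet in this assay. It differs from compound 2 in this way: the two compounds have the same atoms and bonds; at least one stereo element is drawn with a configuration in one of them and without one in the other: 1 of 2 stereo elements differ; a stereocentre at a saturated chain carbon is drawn without a configuration in compound 2 and S in compound 3. For the measured compounds named here, no step between two measured compounds mirrors this change, so there is no measured pair to read a direction from, and the number of compound 1 says nothing about it. With the same atoms and bonds in both compounds and only one stereocentre now drawn with a configuration, a step within the scatter is expected, in no preferred direction. The estimate for compound 3 in this assay is 38%, with a range from 20% to 58%. The estimated step of a number 4 percentage points higher from compound 2 to compound 3 (within the scatter) is expected to stay within the scatter.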

Compound 3, a percentage reported as inhibition, at one concentration (the size of the read-out at that concentration, not a potency): 29%
For compound 3 the middle estimate is 9 percentage points above the measured one; the measured number falls inside the stated range.
By their numbers in this assay, from the lowest: compounds 3 and 2 (each within the scatter of the next); then compound 1.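

Setting the saturated chain carbon as S in one side chain gives, in this assay, a number 5 percentage points lower from compound 2 to compound 3 (within the scatter). For the compounds shown here, this is the first measured pair that differs in one place only, so this position now has a direct reading, which compound 1 could not supply. At the concentration tested, the S drawing and the drawing without a configuration cannot be told apart, and the only structural difference behind that reading is this: the fact that one of compounds 2 and 3 is drawn with a defined configuration and the other without, at the place where they differ

On these data alone, it remains open whether the R configuration at this carbon, or a defined configuration at the matching carbon of the second side chain as well, would read any differently in this assay. Also open, as far as these compounds go, is what an amine or a carboxylic acid in place of a hydroxyl group of this side chain, or a longer chain, would do; compound 1 differs from compound 2 and compound 3 in more than one place and does not settle either question.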